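A few compounds are considered here, and "the series" means these few. Any claim that something is new, unique, unknown or untested is made for them only; others in the source may bear on it.

Measured in a physicochemical assay for solubility, read by spectrophotometry, measured as kinetic solubility, at pH 8, tested at 500 uM; a higher number here means a more soluble compound, a lower number a less soluble compound:
- compound 1 `CN(C)C(=O)c1ccncc1Nc1cc(-c2ccc3ccn(C)c3c2)c2nccnc2c1`: 175 ug/mL
- compound 2 `Cn1ccc2ccc(-c3cc(Nc4cnccc4C(=O)NCc4cncnc4)cc4nccnc34)cc21`: 233 ug/mL
- compound 3 `CC(=O)N1CCCC(NC(=O)c2ccncc2Nc2cc(-c3ccc4ccn(C)c4c3)c3nccnc3c2)C1`: 212 ug/mL

Compound 3 cannot be separated from either of the other two compounds on these numbers. The measured steps are a 1.2-fold higher number from compound 1 to compound 3 (0.08 log units; within the scatter) and a 1.1-fold lower number from compound 2 to compound 3 (0.04 log units; within the scatter), so its place among the three values carries little meaning.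

The next compound is compound 4 `CN1CC(NC(=O)c2ccncc2Nc2cc(-c3ccc4ccn(C)c4c3)c3nccnc3c2)C1`. In it, 1-methylazetidin-3-yl takes the place of 1-acetylpiperidin-3-yl on an amide-type nitrogen: 1-methylazetidin-3-yl in place of 1-acetylpiperidin-3-yl on an amide-type nitrogen. The rest of the molecule stays the same.

Going by the values given here, no measured compound carries the 1-methylazetidin-3-yl group, so there is no direct precedent for this change. The nearest guides are the earlier changes made at this same amide. They are a 1.3-fold higher number from compound 1 to compound 2 (0.12 log units; within the scatter), together with the two steps to compound 3 given above. Compound 1, compound 2 and compound 3 differ only there, and each of those steps stayed small, so a step beyond the scatter is not expected in this assay, and no direction can be favoured with confidence. The estimated change is a 1.1-fold lower number from compound 3 to compound 4 (0.03 log units; within the scatter). For compound 4 the expected value is about 200 ug/mL, with an estimated range of 130 ug/mL to 260 ug/mL.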

Compound 4, solubility: 170 ug/mL
The estimate for compound 4 lay 1.2-fold (0.07 log units) above the measured number; the measured number falls inside the stated range.
By their numbers in this assay, from the lowest: compounds 4, 1, 3 and 2 (each within the scatter of the next).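

In this assay, the four-membered ring of 1-methylazetidin-3-yl brings no separation from the six-membered ring of 1-acetylpiperidin-3-yl (a 1.2-fold lower number from compound 3 to compound 4 (0.10 log units; within the scatter)), even though the group entering is smaller by heavy-atom count and has no double bond outside aromatic rings. The other two comparisons read the same way, with a 1.4-fold lower number from compound 2 to compound 4 (0.14 log units; within the scatter) and a 1.0-fold lower number from compound 1 to compound 4 (0.01 log units; within the scatter), so all four compounds now sit within the scatter of one another, and no listed compound goes against this flat picture at the amide. Nothing measured here bears on what lies behind these numbers.

Whether any group on this amide nitrogen can move the number beyond the scatter remains open, for example a carboxylic acid or a longer chain ending in a primary amine, since neither is among the groups shown. All four compounds also share the same core, so what a change away from this amide would do in this assay is open too.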